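The source may hold more compounds than are shown below. What is called first, only, known or untested is meant among the compounds shown, and "the series" means these compounds.

Working notes on the series. In a functional assay on A2780 cells (Homo sapiens) for antiproliferative activity, with a stated time of 3 days (a lower number here means that less compound is needed, a higher number that more compound is needed for the effect), compound 1 `COc1cc(-c2ccc3nc(NC(C)=O)cn3c2)cnc1N` gives 2000 nM and compound 2 `CCOc1cc(-c2ccc3nc(NC(C)=O)cn3n2)cnc1N` gives 1200 nM; the two numbers lie within the scatter of each other, so no order between compound 1 and compound 2 can be read from them. Compound 3 `CC(=O)Nc1cn2nc(-c3cnc(N)c(C(F)(F)F)c3)ccc2n1` is not yet measured in this assay. It carries trifluoromethyl in place of ethoxy on an aromatic carbon. Among the measured compounds shown here, no measured pair shows the effect of this change, so the step is expected to be small, in no fixed direction, and an expected 1.3-fold higher number from compound 2 to compound 3 (0.10 log units; within the scatter) is taken. For compound 3 the estimate in this assay is 1500 nM, within 500 nM to 5000 nM.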

Compound 3, half-maximal effective concentration: 420 nM
The estimate for compound 3 lay 3.6-fold (0.55 log units) above the measured number, and the stated range ends above it.
By their numbers in this assay, from the lowest: compound 3; then compounds 2 and 1 (each within the scatter of the next).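

In this assay, among the compounds shown here, trifluoromethyl in place of ethoxy on an aromatic carbon, ortho to an amino group, gives a 2.9-fold lower number from compound 2 to compound 3 (0.46 log units; beyond the scatter) and so provides the first step beyond the scatter. This position therefore responds to the group it carries, though the step is modest and rests on one pair. Nothing measured here accounts for the step.

Going by these compounds, whether a chlorine atom, a nitrile or a methyl group at this place would give a similar number remains open. On these data alone, it is also open whether the same change would carry over to the core of compound 1.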